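The source may hold more compounds than are shown below. What is called first, only, known or untested is meant among the compounds shown, and "the series" means these compounds.

Measured so far:
compound 1 `CCOc1ccc(NC(=O)c2ccc(C(CC)(CC)c3ccc(OCCC(O)(CC)CC)c(C)c3)n2CC)cc1` — > 50000 nM
compound 2 `CCC(C)C(NC(=O)c1ccc(C(CC)(CC)c2ccc(OCCC(O)(CC)CC)c(C)c2)n1CC)C(=O)O` — 11300 nM

In a functional assay on MCF7 cells (Homo sapiens) for antiproliferative activity, read by MTT assay, with a stated time of 48 h (on this read-out lower numbers stand for stronger inhibition and higher numbers for weaker inhibition), compound 1 returns > 50000 nM, which is a limit of the assay and not a number. Within the data shown here, compound 2 gives 11300 nM, the only number in the set. The other entry belongs to compound 1 and is a limit: the limit of > 50000 nM in this assay, at which 1 of the 2 values shown sits. Among the measured compounds shown here, the single measured step is an at least 4.4-fold lower number from compound 1 to compound 2 (0.64 log units; beyond the scatter), in which a 1-carboxy-2-methylbutyl group replaced a 4-ethoxyphenyl group on the amide-type nitrogen.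

Compound 3 `CCn1c(C(=O)NC(C)CO)ccc1C(CC)(CC)c1ccc(OCCC(O)(CC)CC)c(C)c1` differs from compound 2 by 1-(hydroxymethyl)ethyl in place of 1-carboxy-2-methylbutyl on an amide-type nitrogen. For the measured compounds named here, no measured step covers this change: the one step that exists concerns the same amide-type nitrogen but swaps an aryl group for the 1-carboxy-2-methylbutyl group, whereas here that group leaves and a smaller 1-(hydroxymethyl)ethyl group enters. Going by the values given here, since compound 2 is the only number available, the expectation for compound 3 rests on it alone and is loose: a step of a 1.8-fold higher number from compound 2 to compound 3 (0.25 log units; within the scatter) is expected, giving an estimated value near 20000 nM, likely between 6000 nM and 60000 nM.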

Compound 3, half-maximal inhibitory concentration: 12600 nM
Beside the measured number, compound 3's estimate is 1.6-fold (0.20 log units) above it; low and high end bracket the measured number.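

In this assay, the step on the amide-type nitrogen is a 1.1-fold higher number from compound 2 to compound 3 (0.05 log units; within the scatter), so the two compounds cannot be told apart, and the carboxy group of 1-carboxy-2-methylbutyl is not needed to reach this level of activity. The other new step is an at least 3.9-fold lower number from compound 1 to compound 3 (0.59 log units; beyond the scatter), so a second group with no ring, in place of 4-ethoxyphenyl, also reads beyond the scatter. Compound 1 remains the one entry that is a limit and not a number: the limit of > 50000 nM in this assay, at which 1 of the 3 values shown sits.

The compounds shown do not separate chain size from the end group, since 1-(hydroxymethyl)ethyl and 1-carboxy-2-methylbutyl differ in both. Open too, from the compounds shown here alone, is whether a basic amine at the chain end, a longer hydroxyalkyl chain, or a phenyl ring carrying a carboxylic acid would give a number clearly apart from those of compound 2 and compound 3.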